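This account rests on a few compounds, and the source may have more. Where it says the series, first, only, none or still open, it means among the compounds named here.

Measured compounds:
compound 1 `Cc1cccc(NNC(=O)c2cccc(NS(=O)(=O)c3cnc(O)nc3O)c2)c1` — > 20000 nM
compound 2 `CCCCOc1ccc(C(=O)NNC(=O)c2ccc(NS(=O)(=O)c3cnc(O)nc3O)cc2)cc1` — 11900 nM

Of the compounds shown here, two on the shared core have been tested in a functional assay on MDA-MB-231 cells (Homo sapiens) for antiproliferative activity, read by MTT assay, with a stated time of 24 h; on this read-out higher numbers stand for weaker inhibition and lower numbers for stronger inhibition. For compound 1 the result is a limit of the assay and not a number: in this assay compound 1 gives > 20000 nM. From the compounds shown here alone, it thus stands at the limit of > 20000 nM in this assay, at which 1 of the 2 values shown sits, and where it would fall as a number is unknown. In this assay compound 2 gives 11900 nM. Going by the values given here, no step between measured compounds that differ in one place exists here, so the two values can only be set side by side.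

Compound 3 `O=C(NNC(=O)c1ccccc1F)c1cccc(NS(=O)(=O)c2cnc(O)nc2O)c1` is not yet measured. It differs from compound 1 by (2-fluorophenyl)carbonyl in place of 3-methylphenyl on an amine nitrogen. Because compound 1 shows only > 20000 nM, the size of the step from it cannot be read from the data; a step toward stronger inhibition, or none beyond the scatter, is expected. Compound 3 is expected to give 15000 nM, within 5000 nM to 40000 nM. The expected change this implies, an at least 1.3-fold lower number from compound 1 to compound 3 (0.12 log units; that floor lies within the scatter), is an estimate only.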

Compound 3, half-maximal inhibitory concentration: > 20000 nM
Compound 3: a limit, no number (the forecaster's own chance of this, stated with the estimate: 45%); middle value at least 1.3-fold (0.12 log units) away from the limit.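

Going by these compounds alone, no step from compound 1 to compound 3 can be read, since each gives only a limit of the assay and not a number: the limit of > 20000 nM in this assay, at which 2 of the 3 values shown sit.

The compounds shown leave open where compound 1 and compound 3 would fall as numbers, and whether (2-fluorophenyl)carbonyl in place of 3-methylphenyl changes inhibition at all.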